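Methoxy addition on two cores in a cytotoxicity series

The compounds below may be only part of what the source reports. "The series", "measured", "known", "first", "only" and "open" are said of these compounds alone.

Measured compounds, with values in an ADME assay on THP-1 cells (Homo sapiens) for cytotoxicity, read by flow cytometry and propidium iodide staining, with a stated time of 72 h; on this read-out higher numbers stand for weaker inhibition and lower numbers for stronger inhibition:
compound 1, `CC(=O)Nc1ccc2oc(-c3ccccc3)cc(=O)c2c1`: 97000 nM
compound 2, `COc1ccccc1-c1cc(=O)c2cc(NC(C)=O)ccc2o1`: 50000 nM
compound 3, `Nc1ccc2oc(-c3ccccc3)c(O)c(=O)c2c1`: 27000 nM

Compound 1 and compound 2 share one core; compound 3 carries a different one, and the difference between the two cores is not broken down here. Within the first pair a single change is recorded, (methoxy in place of hydrogen on an aromatic carbon), and it gave a 1.9-fold lower number from compound 1 to compound 2 (0.29 log units; within the scatter). Compound 3 and compound 2 lie within the scatter of each other; compound 3 against compound 1 is a gap beyond the scatter.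

Compound 4, `COc1cccc(-c2oc3ccc(N)cc3c(=O)c2O)c1`, is not yet measured. It arises from compound 3 by methoxy in place of hydrogen on an aromatic carbon. This is the same kind of change as that from compound 1 to compound 2, not the same: in the earlier case the methoxy enters ortho to a large group, here it enters meta to a large group. For the measured compounds named here, on the strength of the earlier step, compound 4 is expected to give a step of about a 1.5-fold lower number from compound 3 to compound 4 (0.18 log units; within the scatter) in this assay, because the earlier result was a 1.9-fold lower number from compound 1 to compound 2 (0.29 log units; within the scatter) and only one such step is available. The estimate for compound 4 is 18000 nM, with a range from 8000 nM to 45000 nM.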

Compound 4, half-maximal inhibitory concentration: 2000 nM
Compound 4: the middle estimate sits 9.0-fold (0.95 log units) above what was measured; measured number below the stated range.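

In this assay, methoxy in place of hydrogen on an aromatic carbon gives a 14-fold lower number from compound 3 to compound 4 (1.13 log units; beyond the scatter), so the step is large on the core of compound 3. Carried from one core to the other, the change does not keep its size: the same change on two cores in this assay, a 1.9-fold lower number (0.29 log units; within the scatter) from compound 1 to compound 2 and a 14-fold lower number (1.13 log units; beyond the scatter) from compound 3 to compound 4, 7.0-fold (0.84 log units) apart, beyond the scatter of two such steps This does not show that the core alone sets the size of the step: in compound 4 the methoxy sits meta to a large group and in compound 2 it does not, so core and placement are not separated, and two steps give no rule for any further core.

Open, from the compounds shown here alone, is whether a methoxy meta to a large group on the core of compound 1 would give a step like the one on the core of compound 3. Also open, going by these compounds, is whether that large step belongs to methoxy itself or would recur with an ethoxy group, a hydroxyl group or a fluorine atom in the same place.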